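The source may report more compounds than this note shows. Statements on the series, on what has been measured and on what is new or still open speak of the compounds shown alone.

Measured so far in an ADME assay on the whole organism with Oryza sativa as the target, tested at 10 uM; a higher number here means a weaker effect of the compound at the concentration tested, a lower number a stronger effect:
compound 1 `CCc1cccc(NC(=O)N[C@H](C)c2ccccc2)c1` gives 36%
compound 2 `CCc1cccc(NC(=O)N[C@@H](C)c2ccccc2)c1` gives 86%
compound 3 `C[C@H](NC(=O)Nc1ccc(C(C)(C)C)cc1)c1ccccc1` gives 64%

Compound 2 stands highest of these three numbers in this assay, with compound 3 nearest below it and compound 1 furthest below. Among the compounds with values here, the only measured step between single-change pairs is a number 50 percentage points higher from compound 1 to compound 2 (beyond the scatter), and it rests on (the fact that compounds 1 and 2 differ only in the configuration as drawn), a change of configuration alone.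

Compound 4 `C[C@H](NC(=O)Nc1cccc(F)c1)c1ccccc1` differs from compound 2 by fluoro in place of ethyl on an aromatic carbon. Within the data shown here, no measured step touches a group on that aromatic carbon, so the configuration step gives no guide to this exchange, and no step beyond the scatter is expected in this assay. Compound 4 is therefore expected to give about 80%, within a range from 55% to 100%. The expected step is a number 6 percentage points lower from compound 2 to compound 4 (within the scatter).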

Compound 4, a percentage reported as activity, at one concentration (the size of the read-out at that concentration, not a potency): 88%
Compound 4: middle estimate off by 8 percentage points, on the low side; the measured number falls inside the stated range.
By their numbers in this assay, from the lowest: compound 1; then compound 3; then compounds 2 and 4 (each within the scatter of the next).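

In this assay, putting fluoro in place of ethyl on this aromatic carbon yields a number 2 percentage points higher from compound 2 to compound 4 (within the scatter) and so leaves the read-out where it was. The earlier compounds shown here showed only that configuration can move this number; this pair shows that a group on this carbon can change, from two carbons to a single fluorine, without a step beyond the scatter. Nothing shown here accounts for why this exchange has so little effect.

On these data alone, whether an amine or a carboxylic acid on this aromatic carbon would also hold the number stays open. So does whether fluoro in place of ethyl would behave the same way in the configuration of compound 1.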